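A few compounds are considered here, and "the series" means these few. Any claim that something is new, unique, unknown or untested is made for them only; others in the source may bear on it.

Measured so far in an ADME assay for permeability, using PAMPA, with a stated time of 30 min, at pH 7.4; a higher number here means that the compound crosses the layer faster, a lower number that the compound crosses the layer more slowly:
compound 1 `COc1ccc(-c2ccc3c(NCCCNCc4cccc(OC)c4O)ccnc3c2)cc1`: 237 10^-6 cm/s
compound 2 `c1ccc(CCc2ccc3c(NCCCNCc4ccco4)ccnc3c2)cc1`: 23 10^-6 cm/s
compound 3 `COc1ccc(F)cc1CNCCCNc1ccnc2cc(Cc3ccc(F)cc3Cl)ccc12`: 23 10^-6 cm/s

Compound 2 stands level with compound 3 at the digits shown, the two together giving the lowest numbers of the three; the gap between them lies within the scatter. Compound 1 gives a number higher than compound 2 by more than the scatter, but compound 1 differs from compound 2 in more than one place, so no single step can be read from that pair.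

Compound 4 `c1ccc(-c2ccc3c(NCCCNCc4ccco4)ccnc3c2)cc1` has not yet been measured in this assay. Compared with compound 2 it carries phenyl in place of phenethyl on an aromatic carbon.

Among the compounds with values here, no measured pair isolates this change. Compound 1, which gives 237 10^-6 cm/s, likewise carries a phenyl rather than a phenethyl on its core, but it differs from compound 2 elsewhere as well, so that pair cannot settle the matter. A moderate upward step is expected, while no change beyond the scatter would also fit the data in hand. The estimate for compound 4 is 45 10^-6 cm/s, range 15 10^-6 cm/s to 140 10^-6 cm/s, which means an expected step of a 2.0-fold higher number from compound 2 to compound 4 (0.29 log units; within the scatter).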

Compound 4, apparent permeability: 237 10^-6 cm/s
Compound 4: middle estimate off by 5.3-fold (0.72 log units), on the low side; the whole stated range lies below it.
By their numbers in this assay, from the lowest: compounds 2 and 3 (each within the scatter of the next); then compounds 1 and 4 (each within the scatter of the next).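

In this assay, phenyl in place of phenethyl on an aromatic carbon of the shared core gives a 10-fold higher number from compound 2 to compound 4 (1.01 log units; beyond the scatter) with the rest of the structure held fixed. Within the data shown here, this is the only single-place step so far, and it shows that the group at this position can by itself move the read-out well beyond the scatter. No measurement in hand bears on why the step is this large.

Whether the read-out follows the length of the link between this aromatic ring and the core remains open, as the compounds shown do not say how a phenylpropyl chain or a phenoxy group at this carbon would read. Also open, going by these compounds, is whether the same change gives a step of similar size when the other end of the side chain differs.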